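This account rests on a few compounds, and the source may have more. Where it says the series, first, only, none or still open, it means among the compounds named here.

Compound 1 `COc1ccc(-c2nc(-c3ccc4c(c3)CCC(=O)N4)cs2)cc1OC`: 300 nM
Compound 2 `COc1ccc(-c2nc(-c3ccc4c(c3)CCC(=O)N4)cs2)cc1`: 9000 nM

In a functional assay for inhibition, with Homo sapiens as the target (on this read-out higher numbers stand for weaker inhibition and lower numbers for stronger inhibition), compound 1 has the lower of the two numbers. Compound 3 `COc1cc(-c2nc(-c3ccc4c(c3)CCC(=O)N4)cs2)ccc1SC` is not yet measured. It carries methylsulfanyl in place of methoxy on an aromatic carbon, para to a large group: methylsulfanyl in place of methoxy on an aromatic carbon. Among the measured compounds shown here, the only measured step, a 30-fold higher number from compound 1 to compound 2 (1.48 log units; beyond the scatter), is large, but it removes the other methoxy, which compound 3 keeps. It shows that one change on this ring can move the number far, yet gives no direct size for this replacement. The expected step is modest, towards a higher number, and may stay within the scatter: a 1.7-fold higher number from compound 1 to compound 3 (0.22 log units; within the scatter). For compound 3 the estimated value is 500 nM, with an expected range of 120 nM to 2500 nM.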

Compound 3, half-maximal inhibitory concentration: 400 nM
Beside the measured number, compound 3's estimate is 1.3-fold (0.10 log units) above it; measured number inside the range.
By their numbers in this assay, from the lowest: compounds 1 and 3 (each within the scatter of the next); then compound 2.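

At this position, on an aromatic carbon para to a large group, methylsulfanyl stands in place of methoxy with no change beyond the scatter in this assay (a 1.3-fold higher number from compound 1 to compound 3 (0.12 log units; within the scatter)). The large step seen earlier on this ring (a 30-fold higher number from compound 1 to compound 2 (1.48 log units; beyond the scatter)) removes the other methoxy, so it does not carry over to this position. This swap of oxygen for sulfur is therefore accepted here, at least for methylsulfanyl.

On these data alone, it remains open whether hydrogen, an amine or a longer chain such as ethoxy would be accepted at this position. No data given here explain why the two groups read alike.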